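Aryl amine for cyclohexyl amine on the shared core

The compounds below may be only part of what the source reports. "The series", "measured", "known", "first", "only" and "open" are said of these compounds alone.

Compound 1 `O=C1C=C(NC2CCCCC2)C(=O)c2c1nc1n2[C@H]2OC[C@@H](O)[C@H]2OC1` stands in a functional assay on ECa-109 cells for inhibition, with ECa-109 cell line (Homo sapiens) as the target, read by sulforhodamine B assay (a lower number here means a stronger inhibitor, a higher number a weaker inhibitor), only as a limit: compound 1 gives > 16000 nM. This is the reading at the limit of > 16000 nM in this assay, at which 1 of the 2 values shown sits, so compound 1 carries no number of its own. Compound 2 `O=C1C(Nc2ccc(C(F)(F)F)cc2)=CC(=O)c2c1nc1n2[C@H]2OC[C@@H](O)[C@H]2OC1`, which bears an aromatic amine on the same core, gives 2250 nM in this assay. Compound 3 `CCOc1ccccc1NC1=CC(=O)c2nc3n(c2C1=O)[C@H]1OC[C@@H](O)[C@H]1OC3` differs from compound 1 by 2-ethoxyphenyl in place of cyclohexyl on an amine nitrogen. Going by the values given here, no step between measured compounds covers this change. Compound 2 with its aromatic amine at 2250 nM suggests the direction. The move from compound 1 to compound 3 is expected to be a gain of about an at least 4.5-fold lower number from compound 1 to compound 3 (0.66 log units; beyond the scatter). Compound 3 is estimated at 3500 nM, within 1000 nM to 16000 nM.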

Compound 3, half-maximal inhibitory concentration: 4630 nM
For compound 3 the middle estimate is 1.3-fold (0.12 log units) below the measured one, and the stated range covers the measured number.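

Going by these compounds alone, on an amine nitrogen of the shared core, 2-ethoxyphenyl in place of cyclohexyl gives an at least 3.4-fold lower number from compound 1 to compound 3 (0.53 log units; beyond the scatter) in this assay, the only step here that changes one place. This shows that an aromatic ring carrying an ethoxy group is tolerated at this nitrogen and lowers the number beyond the scatter. Compound 1 gives > 16000 nM, which is a limit and not a number, so the step's true size stays unfixed: the limit of > 16000 nM in this assay, at which 1 of the 3 values shown sits.

Open, as far as these compounds go, is whether the gain follows the aromatic ring itself or the ethoxy group. A plain phenyl or a 2-methoxyphenyl on the same amine nitrogen would separate the two.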